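The source may hold more compounds than are shown below. What is called first, only, known or untested is meant among the compounds shown, and "the series" means these compounds.

Measured compounds:
compound 1 `Fc1cc(-c2nc(N3CCN(c4ncccc4C(F)(F)F)CC3)[nH]c2-c2ccc(C(F)(F)F)cc2)cc(F)c1F` — 7 nM
compound 2 `Cc1nc(N2CCN(c3ncccc3C(F)(F)F)CC2)[nH]c1-c1ccc(C(F)(F)F)cc1` — 628 nM
compound 3 `COC(=O)c1nc(N2CCN(c3ncccc3C(F)(F)F)CC2)[nH]c1-c1ccc(C(F)(F)F)cc1` — 1170 nM

In a functional assay on CHO cells for antagonist activity at transient receptor potential cation channel subfamily V member 1 (Rattus norvegicus), read by calcium flux (a lower number here means a stronger inhibitor, a higher number a weaker inhibitor), compound 3 gives 1170 nM. Of the three numbers it stands at the high end: the gap to compound 1 is large and beyond the scatter (a 170-fold higher number from compound 1 to compound 3 (2.22 log units; beyond the scatter)), whereas the gap to compound 2 is within the scatter (a 1.9-fold higher number from compound 2 to compound 3 (0.27 log units; within the scatter)), so compound 2 and compound 3 cannot be told apart.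

Compound 4 `O=C(NCC1CCCCN1)c1nc(N2CCN(c3ncccc3C(F)(F)F)CC2)[nH]c1-c1ccc(C(F)(F)F)cc1` differs from compound 3 in one place: ((piperidin-2-yl)methyl)amino in place of methoxy on a carbonyl carbon. Going by the values given here, no measured step changes this carbonyl position; the large steps of a 90-fold higher number from compound 1 to compound 2 (1.95 log units; beyond the scatter) and a 170-fold higher number from compound 1 to compound 3 (2.22 log units; beyond the scatter) concern the aromatic carbon, and the only step that leaves the 3,4,5-trifluorophenyl absent, a 1.9-fold higher number from compound 2 to compound 3 (0.27 log units; within the scatter), is within the scatter. The measured steps therefore give no direct guide; the closest reading is that exchanging small groups away from the aromatic carbon has so far moved this assay little. On that basis compound 4 is expected to stay near compound 3, with a step of a 1.5-fold lower number from compound 3 to compound 4 (0.17 log units; within the scatter) that may not exceed the scatter. The estimate for compound 4 in this assay is 800 nM, within a range of 150 nM to 4000 nM.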

Compound 4, half-maximal inhibitory concentration: 2950 nM
Compound 4: middle estimate off by 3.7-fold (0.57 log units), on the low side; the measured number falls inside the stated range.
By their numbers in this assay, from the lowest: compound 1; then compounds 2 and 3 (each within the scatter of the next); then compound 4.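

In this assay, the carbonyl carbon proves able to move the number (a 2.5-fold higher number from compound 3 to compound 4 (0.40 log units; beyond the scatter)), a modest step, whereas the earlier exchange of methyl for methoxycarbonyl on the aromatic carbon stayed within the scatter. Putting ((piperidin-2-yl)methyl)amino, with its six-membered non-aromatic ring, in place of methoxy thus gives a weaker inhibitor, and the same holds against the methyl group on the aromatic carbon (a 4.7-fold higher number from compound 2 to compound 4 (0.67 log units; beyond the scatter)). The 3,4,5-trifluorophenyl group stays far ahead of this amide (a 420-fold higher number from compound 1 to compound 4 (2.62 log units; beyond the scatter)), and nothing measured here explains the loss.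

The compounds shown leave open whether a plain carboxamide, a methylamide or a carboxylic acid at this carbonyl carbon would follow compound 4 or compound 3, so the amide and the piperidine ring cannot be separated. From the compounds shown here alone, whether an unfluorinated phenyl on the aromatic carbon would stay close to compound 1 also remains open.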